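From Carboxy to Carbamoyl: a Solubility Step

The source may report more compounds than this note shows. Statements on the series, on what has been measured and on what is new or still open speak of the compounds shown alone.

Compound 1, `N#Cc1ccc(-c2cnc(N)c(-c3ccc(N)nc3)n2)cc1`: 208000 nM
Compound 2, `Nc1ncc(-c2ccc(C(=O)O)cc2)nc1-c1ccc(C(F)(F)F)cc1`: < 5000 nM

Of the compounds shown here, two have been measured in a physicochemical assay for solubility, read by HPLC, using the shake flask method, with a stated time of 2 h, at pH 2; a lower number here means a less soluble compound, a higher number a more soluble compound. Compound 1 gives 208000 nM in this assay. For compound 2 this assay reports no number, only the limit < 5000 nM, and that limit is where one of the two values sits (the limit of < 5000 nM in this assay, at which 1 of the 2 values shown sits). Compound 2 therefore stands at the low end of what is known here, while compound 1 is clearly soluble.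

The step to be followed leads from compound 2 to compound 3, `NC(=O)c1ccc(-c2cnc(N)c(-c3ccc(C(F)(F)F)cc3)n2)cc1`. The change is amino in place of hydroxy on a carbonyl carbon. For the measured compounds named here, no measured pair shows this change, so its size is open. Since compound 2 is only bounded by a limit, compound 3 is expected to move little, a small rise or none beyond the scatter, as an at least 1.2-fold higher number from compound 2 to compound 3 (0.07 log units; that floor lies within the scatter). Compound 3 is thus estimated at 6000 nM, in the range 1500 nM to 30000 nM.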

Compound 3, solubility: 80000 nM
Compound 3: the middle estimate sits 13-fold (1.12 log units) below what was measured, outside the stated range (above it).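

With this pair, the first in the series to differ in one place, amino in place of hydroxy on a carbonyl carbon proves a large change in this assay, which reads as an at least 16-fold higher number from compound 2 to compound 3 (1.20 log units; beyond the scatter). Carboxy to carbamoyl on this aromatic carbon thus gives a direction and a minimum size for the change, which neither earlier compound could show alone. The step remains a minimum and not an exact size, since compound 2 carries only a limit: the limit of < 5000 nM in this assay, at which 1 of the 3 values shown sits.

As far as these compounds go, how far the step reaches beyond that minimum stays open, as does whether it would hold on a different core. The compounds shown also leave open how a methyl ester or a dimethylamino group on the same carbonyl carbon would read in this assay.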